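A Methoxymethyl Exchange on a Micromolar Pair

A few compounds are considered here, and "the series" means these few. Any claim that something is new, unique, unknown or untested is made for them only; others in the source may bear on it.

In a functional assay on HL-60 cells (Homo sapiens) for antiproliferative activity, read by MTT assay, with a stated time of 48 h (on this read-out lower numbers stand for stronger inhibition and higher numbers for weaker inhibition), compound 1 (`CC(=O)OC/C1=C/C[C@](C)(CCC=C(C)C)/C=C/[C@@H](OC(=O)C=C(C)C)[C@](C)(O)/C=C/C1=O`) gives 2950 nM and compound 2 (`CCCC(=O)O[C@@H]1/C=C/[C@@](C)(CCC=C(C)C)C/C=C(/CO)C(=O)/C=C/[C@@]1(C)O`) gives 4180 nM within the scatter of that value. Going by the values given here, on these numbers, compound 2 stands level with the only other measured compound. Compound 3 (`COCO[C@@H]1/C=C/[C@@](C)(CCC=C(C)C)C/C=C(/CO)C(=O)/C=C/[C@@]1(C)O`) keeps the core of compound 2 but carries methoxymethyl in place of propylcarbonyl on an oxygen on a saturated carbon. Among the compounds with values here, no measured step shows what this exchange does, so any expectation remains loose. Starting from compound 2 at 4180 nM a modest move toward a weaker number in this assay is expected, although a step within the scatter would be no surprise. The expected step is a 1.6-fold higher number from compound 2 to compound 3 (0.19 log units; within the scatter) on this estimate. The estimate for compound 3 is 6500 nM within an expected range of (2500 nM to 17000 nM).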

Compound 3, half-maximal inhibitory concentration: > 40000 nM
Compound 3: no number, only a limit; the forecaster's own chance of this, stated with the estimate: 10%; middle value at least 6.1-fold (0.78 log units) away from the limit.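

Going by these compounds alone, compound 1 and compound 2 offered no single-place comparison, so this is the only measured step at this position: in this assay, methoxymethyl in place of propylcarbonyl gives an at least 9.5-fold higher number from compound 2 to compound 3 (0.98 log units; beyond the scatter). Compound 3 reads > 40000 nM, which is a limit of the assay and not a number. The position is therefore not indifferent to what sits on this oxygen, though the step has only a lower bound and its full size remains unknown: the limit of > 40000 nM in this assay, at which 1 of the 3 values shown sits.

The compounds shown leave open whether a hydroxyl, a methyl ether or a longer acyl chain on this oxygen would stay close to the value of compound 2. They also give no cause for the step, and they do not show whether the same exchange would act alike on another core.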